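The source may report more compounds than this note shows. Statements on the series, on what has been measured and on what is new or still open speak of the compounds shown alone.

Compound 1 `Oc1ccc(-c2cc(-c3ccccc3O)cc(-c3cccc(O)c3)n2)cc1`: 5650 nM
Compound 2 `Oc1ccc(-c2cc(-c3ccccc3O)cc(-c3ccccc3O)n2)cc1`: 6990 nM
Compound 3 `Oc1cccc(-c2cc(-c3ccccc3O)cc(-c3ccccc3O)n2)c1`: 730 nM

All readings come from an ADME assay on HEK293 cells (Homo sapiens) for cytotoxicity, read by CCK-8 assay, with a stated time of 4 days; on this read-out higher numbers stand for weaker inhibition and lower numbers for stronger inhibition. Compound 1 sits with compound 2 at the high end, showing a 1.2-fold higher number from compound 1 to compound 2 (0.09 log units; within the scatter), while the other measured step from it is a 7.7-fold lower number from compound 1 to compound 3 (0.89 log units; beyond the scatter).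

Compound 4 `Oc1ccc(-c2cc(-c3ccc(O)cc3)nc(-c3cccc(O)c3)c2)cc1` is unmeasured and carries this change: 4-hydroxyphenyl in place of 2-hydroxyphenyl on an aromatic carbon. Within the data shown here, the exchange lies opposite the ring nitrogen, a place no measured step alters, so the evidence is indirect. Losing a 4-hydroxyphenyl elsewhere gave a 7.7-fold lower number from compound 1 to compound 3 (0.89 log units; beyond the scatter) and a 9.6-fold lower number from compound 2 to compound 3 (0.98 log units; beyond the scatter). A modest rise in this assay is therefore tentatively expected, with no change beyond the scatter also plausible. The expected step is a 1.4-fold higher number from compound 1 to compound 4 (0.15 log units; within the scatter). For compound 4 the estimated value is 8000 nM, with an expected range of 2000 nM to 30000 nM.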

Compound 4, half-maximal inhibitory concentration: 840 nM
For compound 4 the middle estimate is 9.5-fold (0.98 log units) above the measured one; the measured number lies below the stated range.
By their numbers in this assay, from the lowest: compounds 3 and 4 (each within the scatter of the next); then compounds 1 and 2 (each within the scatter of the next).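

In this assay, the place opposite the ring nitrogen responds to substitution: 4-hydroxyphenyl in place of 2-hydroxyphenyl gives a 6.7-fold lower number from compound 1 to compound 4 (0.83 log units; beyond the scatter) on the core of compound 1. The groups that leave and enter have the same heavy atoms, donor count and acceptor count, so moving the hydroxyl around this one ring is enough to give a step beyond the scatter. Nothing at hand accounts for this step.

Still open, as far as these compounds go, is how this place would read with an unsubstituted phenyl, a methoxyphenyl or an aminophenyl. Also open, from the compounds shown here alone, is whether the same exchange would give a similar step on the core of compound 2 or compound 3.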